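Chloro to methyl: the step from compound 2 to compound 3

The compounds below may be only part of what the source reports. "The series", "measured", "known", "first", "only" and "open" are said of these compounds alone.

Measured compounds:
compound 1, `O=C(NCc1ccc(C(F)(F)F)nc1N1CCCCC1)Nc1cccc2[nH]c(=O)ccc12`, gives 0.75 nM in an assay on HEK cells for antagonist activity at transient receptor potential cation channel subfamily V member 1 (Homo sapiens), read by FLIPR; on this read-out lower numbers stand for stronger inhibition and higher numbers for weaker inhibition.
compound 2, `O=C(NCc1cc(C(F)(F)F)nn1-c1cccc(Cl)c1)Nc1cccc2[nH]c(=O)ccc12`, gives 1.71 nM in this assay.

For the measured compounds named here, of the two numbers measured so far, compound 2 stands at the higher one. Its nearest neighbour is compound 1, whose lower number lies beyond the usual scatter of this kind of measurement, so compound 1 is the stronger inhibitor of the pair. Going by the values given here, the two compounds differ in several places at once, and no single step between them is broken out, so their values show only that both sit in the low nanomolar region.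

Compound 3, `Cc1cccc(-n2nc(C(F)(F)F)cc2CNC(=O)Nc2cccc3[nH]c(=O)ccc23)c1`, is not yet measured. It differs from compound 2 in one place: methyl in place of chloro on an aromatic carbon. Among the compounds with values here, nothing among the measured compounds isolates a change of this kind, so there is no measured step to lean on. A swap of one single heavy atom for another on the same aromatic carbon, with no change in ring count, donors or acceptors, is expected to move the number little. The step from compound 2 to compound 3 is therefore estimated as a 1.2-fold higher number from compound 2 to compound 3 (0.07 log units; within the scatter), a change within the usual scatter in either direction. For compound 3 the expected value in this assay is 2 nM, with a range from 0.8 nM to 5 nM.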

Compound 3, half-maximal inhibitory concentration: 0.64 nM
Compound 3: the middle estimate sits 3.1-fold (0.49 log units) above what was measured, outside the stated range (below it).
By their numbers in this assay, from the lowest: compounds 3 and 1 (each within the scatter of the next); then compound 2.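

In this assay the change from 3-chlorophenyl to 3-methylphenyl, made on an aromatic carbon meta to a large group, gives a 2.7-fold lower number from compound 2 to compound 3 (0.43 log units; beyond the scatter) and so counts as a modest step. For the compounds shown here, this is the first single-place comparison, and it shows that the number responds to the group at this position, even when one heavy atom replaces another and neither brings a ring, a hydrogen-bond donor or acceptor, or a net charge. No measurement shown here explains why methyl gives the lower number at this position.

The compounds shown carry only chloro and methyl at this position, so it remains open whether an ethyl chain, a methoxy group or an amine on the same aromatic carbon would lower the number further or raise it again. Going by these compounds, it also remains open whether methyl in place of chloro would give a step of similar size and direction on a different aromatic ring or in the core of compound 1.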